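Replacing an Acid with a Morpholine Amide on a Shared Core

A few compounds are considered here, and "the series" means these few. Any claim that something is new, unique, unknown or untested is made for them only; others in the source may bear on it.

Compound 1 `COc1ccc2c(c1)cc(CNCc1ccccc1)n2C`: > 100000 nM; 100000 nM (2 entries)
Compound 2 `Cn1c(C(=O)O)cc2cc(OCCCC3CCN(Cc4ccccc4)CC3)ccc21`: > 100000 nM

Both measured compounds were tested in an assay on isolated protein for inhibition of Amine oxidase [flavin-containing] B (Homo sapiens), read by fluorescence, with stated times of 30 min and 1 h; on this read-out higher numbers stand for weaker inhibition and lower numbers for stronger inhibition. Compound 1 gave > 100000 nM; 100000 nM (2 entries) across its several entries in this assay (the several entries of compound 1 in this assay, > 100000 nM; 100000 nM (2 entries)). Compound 2 is known only as a limit, > 100000 nM, so it sits at the edge of what this assay can report (the limit of > 100000 nM in this assay, at which 1 of the 2 values shown sits). On the numbers shown, compound 2 therefore stands no better than compound 1, and neither shows measurable inhibition.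

Compound 3 `Cn1c(C(=O)N2CCOCC2)cc2cc(OCCCC3CCN(Cc4ccccc4)CC3)ccc21` differs from compound 2 in one place: morpholin-4-yl in place of hydroxy on a carbonyl carbon, that is, a carboxy group becomes a (morpholin-4-yl)carbonyl group. Within the data shown here, no measured pair shows what this change does here, so the expectation rests on the weak starting point alone. The step from compound 2 to compound 3 is expected to be none beyond the scatter, as a number no higher from compound 2 to compound 3 (the limit leaves the size open). Compound 3 is estimated at 100000 nM, within a range of 30000 nM to 300000 nM, with a real chance that this assay again returns only a limit.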

Compound 3, half-maximal inhibitory concentration: > 100000 nM
Compound 3 ended at the assay's limit; the forecaster's own chance of this, stated with the estimate: 65%; the middle value lies on the limit itself.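

Compound 2 and compound 3 both stand only as limits in this assay, and no step can be read between them. The compounds shown leave open whether morpholin-4-yl in place of hydroxy on a carbonyl carbon changes inhibition at all, and which change to the shared core, if any, would give a measurable value.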